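This account rests on a few compounds, and the source may have more. Where it says the series, first, only, none or still open, it means among the compounds named here.

Working notes on the series. Compound 1 `CCC(Nc1nc(C)nc2c1nnn2-c1ccc(C(C)C)cc1Br)C(=O)OC` gives 19.4 nM in an in vitro assay on 293-EBNA cells for binding affinity to corticotropin-releasing factor receptor 1 (Homo sapiens) (on this read-out lower numbers stand for stronger inhibition and higher numbers for weaker inhibition), and compound 2 `CCCCC(CCCC)Nc1nc(C)nc2c1nnn2-c1ccc(C(C)C)cc1Br` gives 4.5 nM. Going by the values given here, the single one-place step measured so far is a 4.3-fold lower number from compound 1 to compound 2 (0.63 log units; beyond the scatter), where 1-butylpentyl in place of 1-(methoxycarbonyl)propyl on a nitrogen on an aromatic ring went with the lower number. Compound 3 `COCCNc1nc(C)nc2c1ncn2-c1ccc(C(C)C)cc1Br` gives 210 nM, the highest of the three numbers, beyond the scatter from both compound 1 and compound 2.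

Compound 4 `CCC(COC)Oc1nc(C)nc2c1ncn2-c1ccc(C(C)C)cc1Br` carries 1-(methoxymethyl)propoxy in place of (2-methoxyethyl)amino on an aromatic carbon. Among the compounds with values here, no measured step covers an ether in place of an amine, and that one step sits on a different core, so it bears only loosely; it is modest, and a branched chain enters here as well. For compound 4 the expected step is a 4.2-fold lower number from compound 3 to compound 4 (0.62 log units; beyond the scatter) in the direction of a lower number. The estimate for compound 4 in this assay is 50 nM, with a range of 12 nM to 200 nM.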

Compound 4, inhibition constant: 9.7 nM
Compound 4: middle estimate off by 5.2-fold (0.71 log units), on the high side; the whole stated range lies above it.
By their numbers in this assay, from the lowest: compound 2; then compounds 4 and 1 (each within the scatter of the next); then compound 3.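

On the core shared by compound 3 and compound 4, 1-(methoxymethyl)propoxy in place of (2-methoxyethyl)amino on the aromatic carbon next to the ring nitrogen gives a 22-fold lower number from compound 3 to compound 4 (1.34 log units; beyond the scatter) in this assay, a large step. A low number at this position therefore does not require a hydrogen-bond donor on the substituent, as the entering group has 0 hydrogen-bond donors. Nothing available explains the size of this step. Still open, going by these compounds, is whether the step follows the ether oxygen or the branched chain: 1-(methoxymethyl)propylamino or 2-methoxyethoxy on this carbon would separate the two.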